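The compounds below may be only part of what the source reports. "The series", "measured", "known", "first", "only" and "open" are said of these compounds alone.

Measured so far:
compound 1 `O=C(/C=C/c1cccs1)c1cc(O)c(O)c([N+](=O)[O-])c1` — 190 nM
compound 2 `CC(=O)N1N=C(c2cc(O)c(O)c([N+](=O)[O-])c2)CC1c1cccc(C#N)c1` — 79 nM
compound 3 `N#Cc1ccc(/C=C/C(=O)c2cc(O)c(O)c([N+](=O)[O-])c2)cc1` — 180 nM

All three numbers come from an assay for inhibition of Catechol O-methyltransferase (Rattus norvegicus), read by fluorescence and spectrophotometry; a higher number here means a weaker inhibitor, a lower number a stronger inhibitor. Compound 1 carries the highest number of the three; compound 3 sits within the scatter of it, while compound 2 lies beyond the scatter on the lower side. Compound 4 `O=C(/C=C/c1nccs1)c1cc(O)c(O)c([N+](=O)[O-])c1` differs from compound 1 in one place (1,3-thiazol-2-yl in place of thiophen-2-yl on a double-bonded chain carbon bound to a double-bonded chain carbon). Going by the values given here, no measured pair spans this change, so its size is unknown from the series itself; the expectation is a step in this assay no larger than the scatter, if anything toward a higher number. Compound 4 is therefore expected to give 260 nM in this assay, with a range from 110 nM to 620 nM. That estimate corresponds to an expected step of a 1.4-fold higher number from compound 1 to compound 4 (0.14 log units; within the scatter).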

Compound 4, half-maximal inhibitory concentration: 240 nM
Compound 4: middle estimate off by 1.1-fold (0.03 log units), on the high side; low and high end bracket the measured number.
By their numbers in this assay, from the lowest: compound 2; then compounds 3, 1 and 4 (each within the scatter of the next).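

In this assay, going by these compounds alone, 1,3-thiazol-2-yl in place of thiophen-2-yl on a double-bonded chain carbon bound to a double-bonded chain carbon gives a 1.3-fold higher number from compound 1 to compound 4 (0.10 log units; within the scatter) and is the first step read at this position. Exchanging one five-membered aromatic ring for the other, with one more hydrogen-bond acceptor counted, leaves the number within the scatter. No measured evidence bears on the size of this step. The compounds shown leave open whether an amine, a carboxylic acid or a longer chain at this position would move the number beyond the scatter.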